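Adding bromo to the phenyl ring of compound 3

A few compounds are considered here, and "the series" means these few. Any claim that something is new, unique, unknown or untested is made for them only; others in the source may bear on it.

Values in a functional assay on L1210 cells (Mus musculus) for antiproliferative activity, read by MTT assay, with a stated time of 72 h (a higher number here means a weaker inhibitor, a lower number a stronger inhibitor), follow.
- compound 1 `COc1cc(C2=NN(C(C)=O)C(c3ccc([N+](=O)[O-])cc3)O2)cc(OC)c1OC` gives 4200 nM
- compound 2 `COc1cccc(C2OC(c3cc(OC)c(OC)c(OC)c3)=NN2C(C)=O)c1` gives 45000 nM
- compound 3 `COc1cc(C2=NN(C(C)=O)C(c3ccccc3)O2)cc(OC)c1OC` gives 6400 nM

Compound 3 stands at the low end of these numbers, together with compound 1, and only compound 2 is clearly higher. Losing the nitro group shows no real change: a 1.5-fold higher number from compound 1 to compound 3 (0.18 log units; within the scatter). Losing the methoxy group of the 3-methoxyphenyl ring matters more: a 7.0-fold lower number from compound 2 to compound 3 (0.85 log units; beyond the scatter).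

Compound 4 `COc1cc(C2=NN(C(C)=O)C(c3cccc(Br)c3)O2)cc(OC)c1OC` differs from compound 3 by bromo in place of hydrogen on an aromatic carbon. Going by the values given here, no measured step involves bromo, so compound 2 is the only guide, and a partial echo of its step is expected in this assay. The expected step is small, towards a higher number and not clearly beyond the scatter: a 1.7-fold higher number from compound 3 to compound 4 (0.24 log units; within the scatter). For compound 4 the estimated value is 11000 nM, with an expected range of 3500 nM to 35000 nM.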

Compound 4, half-maximal inhibitory concentration: 600 nM
The estimate for compound 4 lay 18-fold (1.26 log units) above the measured number; the measured number lies below the stated range.
By their numbers in this assay, from the lowest: compound 4; then compounds 1 and 3 (each within the scatter of the next); then compound 2.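

In this assay, going by these compounds alone, this place on the phenyl ring turns out to reward a substituent, which the earlier compounds did not show: an 11-fold lower number from compound 3 to compound 4 (1.03 log units; beyond the scatter). The group itself decides the direction, since methoxy at the same place gave a higher number than hydrogen, while bromo gives a lower one: a 75-fold lower number from compound 2 to compound 4 (1.88 log units; beyond the scatter). The 3-bromophenyl compound also clearly separates from the 4-nitrophenyl compound: a 7.0-fold lower number from compound 1 to compound 4 (0.85 log units; beyond the scatter).

From the compounds shown here alone, whether chloro, an amine or a carboxylic acid at this place would follow bromo remains open. Nothing available accounts for the size of the bromo step.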